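The source may report more compounds than this note shows. Statements on the series, on what has been measured and on what is new or still open speak of the compounds shown alone.

Compound 1 `O=C(NCCCCc1ccccc1)n1cc(-c2ccccc2)oc1=O` carries a phenyl group on the shared core. Among the compounds with values here, in an ADME assay on microsomes from liver (Mus musculus) for metabolic stability, read by LC-MS, using NADPH, tested at 4.6 uM (a higher number here means that the compound lasts longer, a lower number that the compound disappears faster), compound 1 gives 0.667 h, and this is the only plain number in the set. Compound 2 `O=C(NCCCCc1ccccc1)n1cc(-c2cccnc2)oc1=O` bears a pyridin-3-yl group in place of that phenyl. In this assay compound 2 gives > 1 h, which is a limit of the assay rather than a number. The step of an at least 1.4-fold higher number from compound 1 to compound 2 (0.17 log units; that floor lies within the scatter) therefore has a floor that lies within the scatter, and how far beyond that floor the true change reaches is not known; the step rests on (the limit of > 1 h in this assay, at which 1 of the 2 values shown sits). Compound 3 `O=C(NCCCCc1ccccc1)n1cc(-c2ccncc2)oc1=O` differs from compound 1 by pyridin-4-yl in place of phenyl on an aromatic carbon. Within the data shown here, the single measured step that bears on this change is the one to compound 2, where only a small floor is recorded; the incoming group is a pyridinyl like that of compound 2, so a comparable outcome is expected. For compound 3 the step of a 1.8-fold higher number from compound 1 to compound 3 (0.26 log units; within the scatter) is expected in this assay, a modest rise if any. Compound 3 is therefore estimated at 1.2 h, within 0.6 h to 2.5 h, and the assay may again report only a limit.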

Compound 3, half-life: > 1 h
Compound 3 ended at the assay's limit (the forecaster's own chance of this, stated with the estimate: 55%); the middle value is on the limit's open side.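

Within the data shown here, compound 3 is also reported only as a limit of the assay, so at this place on the shared core, next to the ring oxygen, a second pyridinyl group now stands in this assay where the earlier compounds offered only one. The step of an at least 1.4-fold higher number from compound 1 to compound 3 (0.17 log units; that floor lies within the scatter) carries the same floor as the step of an at least 1.4-fold higher number from compound 1 to compound 2 (0.17 log units; that floor lies within the scatter), so both pyridinyl groups are compatible with a half-life longer than that of compound 1, yet neither floor by itself lies beyond the scatter. The steps between the two pyridinyl compounds cannot be read, and the shift of the ring nitrogen from pyridin-3-yl to pyridin-4-yl therefore has no visible size in either direction: the limit of > 1 h in this assay, at which 2 of the 3 values shown sit.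

As far as these compounds go, how far compound 2 and compound 3 truly lie past the limit stays unknown, and with it whether either change amounts to more than the usual scatter. Also open, from the compounds shown here alone, is whether a pyrimidinyl group, or a phenyl ring carrying an amine or a carboxylic acid, at this same place would give a half-life that can be read as a number.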